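Swapping a methoxy for two chlorines on the benzyl

The compounds below may be only part of what the source reports. "The series", "measured", "known", "first", "only" and "open" are said of these compounds alone.

Compound 1, `CC(C)(C)OC(=O)N1CCN(C(=S)SCc2cn(-c3ccccc3F)nn2)CC1`, gives > 128000 nM in a functional assay on ECa-109 cells (Homo sapiens) for inhibition, read by MTT assay, with a stated time of 72 h (on this read-out higher numbers stand for weaker inhibition and lower numbers for stronger inhibition), a limit of the assay rather than a number.
Compound 2, `CC(C)(C)OC(=O)N1CCN(C(=S)SCc2cn(Cc3ccc(Cl)cc3)nn2)CC1`, gives > 128000 nM in this assay, again a limit.
Compound 3, `COc1ccc(Cn2cc(CSC(=S)N3CCN(C(=O)OC(C)(C)C)CC3)nn2)cc1`, gives 36800 nM in this assay.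

Among the compounds with values here, compound 3 therefore stands as the only compound of the three with an actual number; the other two values are limits. Compound 4, `CC(C)(C)OC(=O)N1CCN(C(=S)SCc2cn(Cc3ccc(Cl)c(Cl)c3)nn2)CC1`, has not yet been measured. It differs from compound 3 in one place: 3,4-dichlorophenyl in place of 4-methoxyphenyl on a saturated chain carbon bound to an aromatic nitrogen.

Within the data shown here, two measured steps bear on this. The step of an at least 3.4-fold lower number from compound 2 to compound 3 (0.54 log units; beyond the scatter) shows that exchanging chloro for methoxy lowered the number; compound 4 runs that exchange backwards and adds a second chloro. The step that the two limits leave unreadable from compound 1 to compound 2 cannot be read, since both values sit at the limit (the limit of > 128000 nM in this assay, at which 2 of the 3 values shown sit). A higher number is therefore expected for compound 4, the step being estimated as a 2.7-fold higher number from compound 3 to compound 4 (0.43 log units; beyond the scatter), possibly reaching the limit. Compound 4 is estimated at 100000 nM, between 30000 nM and 250000 nM.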

Compound 4, half-maximal inhibitory concentration: > 128000 nM
Compound 4 gave a limit, no number; the forecaster's own chance of this, stated with the estimate: 55%; middle value at least 1.2-fold (0.10 log units) away from the limit.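

Replacing 4-methoxyphenyl with 3,4-dichlorophenyl gives an at least 3.4-fold higher number from compound 3 to compound 4 (0.54 log units; beyond the scatter) in this assay, so the loss seen with one chloro in place of the methoxy also appears when the ring carries two chlorines. Compound 4 gives > 128000 nM, which is a limit and not a number. The steps from compound 1 and from compound 2 to compound 4 cannot be read, so the second chloro has no size of its own here: the limit of > 128000 nM in this assay, at which 3 of the 4 values shown sit.

Among the benzyl compounds shown, compound 3 alone gives a number, 36800 nM, which leaves open whether the methoxy itself matters or only the absence of chlorine. A plain unsubstituted benzyl, an ethoxy or a hydroxyl in the methoxy's place, or a dimethylamino group on that ring could help separate these possibilities.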